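The source may hold more compounds than are shown below. What is called first, only, known or untested is meant among the compounds shown, and "the series" means these compounds.

Of the compounds shown here, three with the shared core have been measured in a functional assay on B16 cells (Mus musculus) for antiproliferative activity, read by MTT assay, with a stated time of 24 h (on this read-out lower numbers stand for stronger inhibition and higher numbers for weaker inhibition), so far. Compound 1 `COc1cc(OC)c(-c2coc3cc(OCc4ccccc4)ccc3c2=O)cc1OC` gives 2330 nM and compound 2 `COc1cc(OC)c(-c2coc3cc(OCc4ccccc4F)ccc3c2=O)cc1OC` gives 1610 nM in this test of cell growth. Compound 3 `COc1cc(OC)c(-c2coc3cc(OCc4ccccc4C)ccc3c2=O)cc1OC` gives 2150 nM and cannot be told apart from the other two: the measured steps are a 1.1-fold lower number from compound 1 to compound 3 (0.03 log units; within the scatter) and a 1.3-fold higher number from compound 2 to compound 3 (0.13 log units; within the scatter) and both lie within the scatter.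

Compound 4 `COc1cc(OC)c(-c2coc3cc(OCc4ccccc4C(F)(F)F)ccc3c2=O)cc1OC` follows from compound 3 by one change trifluoromethyl in place of methyl on an aromatic carbon that puts trifluoromethyl in place of methyl on an aromatic carbon, ortho to a large group. Among the measured compounds shown here, three measured steps bear on it, all at this same place: fluoro for hydrogen a 1.4-fold lower number from compound 1 to compound 2 (0.16 log units; within the scatter) and the two steps above. For the measured compounds named here, none goes beyond the scatter, although no measured compound yet carries trifluoromethyl, so this guide is limited. The expected step is a 1.1-fold lower number from compound 3 to compound 4 (0.05 log units; within the scatter) with no clear direction and nothing expected beyond the scatter. Compound 4 is estimated at 1900 nM (expected range 1000 nM to 3600 nM).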

Compound 4, half-maximal inhibitory concentration: 8550 nM
Compound 4: the middle estimate sits 4.5-fold (0.65 log units) below what was measured; measured number above the stated range.
By their numbers in this assay, from the lowest: compounds 2, 3 and 1 (each within the scatter of the next); then compound 4.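

Hydrogen, fluoro and methyl on this aromatic carbon, ortho to a large group, could not be told apart in this assay, so the position looked indifferent to the choice of group. Trifluoromethyl ends that picture: replacing methyl gives a 4.0-fold higher number from compound 3 to compound 4 (0.60 log units; beyond the scatter) and replacing fluoro gives a 5.3-fold higher number from compound 2 to compound 4 (0.73 log units; beyond the scatter) and replacing hydrogen gives a 3.7-fold higher number from compound 1 to compound 4 (0.56 log units; beyond the scatter) on the same carbon. Among the compounds shown here, all three steps point towards weaker inhibition, so this position does respond to what sits there, although compound 4 is the only compound that shows it.

Nothing measured here explains why trifluoromethyl behaves differently from methyl. On these data alone, it also remains open whether an amine, a carboxylic acid or a longer chain on this carbon would weaken inhibition in the same way.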